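The source may report more compounds than this note shows. Statements on the series, on what has been measured and on what is new or still open speak of the compounds shown alone.

Compound 1 `CCCN(CC[C@H]1CC[C@H](NC(=O)/C=C/c2ccccc2Cl)CC1)[C@H]1CCc2nc(N)sc2C1` gives 1.2 nM in an assay on brain for displacement of a labelled ligand from D(3) dopamine receptor (Rattus norvegicus); on this read-out higher numbers stand for weaker inhibition and lower numbers for stronger inhibition.
Compound 2 `CCCN(CC[C@H]1CC[C@H](NC(=O)c2cccc3cnccc23)CC1)[C@H]1CCc2nc(N)sc2C1` gives 5.9 nM in this assay.

Compound 1 holds the lowest of the two numbers; its nearest neighbour is compound 2, reached by a 4.9-fold higher number from compound 1 to compound 2 (0.69 log units; beyond the scatter). Compound 3 `CCCN(CC[C@H]1CC[C@H](NS(=O)(=O)c2cccc(C)c2)CC1)[C@H]1CCc2nc(N)sc2C1` is not yet measured. It differs from compound 1 in one place: (3-methylphenyl)sulfonyl in place of (2-(2-chlorophenyl)ethenyl)carbonyl on an amine nitrogen. Among the measured compounds shown here, only the step from compound 1 to compound 2 bears on this, as the one replacement of the carbonyl-bearing group that is known; it was modest, and the sulfonyl group of compound 3 is a larger departure. The number for compound 3 is therefore expected to rise by an 8.3-fold higher number from compound 1 to compound 3 (0.92 log units; beyond the scatter). Compound 3 is estimated at 10 nM, within 2 nM to 60 nM.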

Compound 3, inhibition constant: 0.89 nM
For compound 3 the middle estimate is 11-fold (1.05 log units) above the measured one, and the stated range ends above it.
By their numbers in this assay, from the lowest: compounds 3 and 1 (each within the scatter of the next); then compound 2.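

At the amine nitrogen, the carbonyl link is not needed to keep the number low in this assay: the step of a 1.3-fold lower number from compound 1 to compound 3 (0.13 log units; within the scatter) replaces both the link and the 2-(2-chlorophenyl)ethenyl group. The earlier step, a 4.9-fold higher number from compound 1 to compound 2 (0.69 log units; beyond the scatter), had changed only the group on a retained carbonyl. Nothing available explains why the (3-methylphenyl)sulfonyl and (2-(2-chlorophenyl)ethenyl)carbonyl groups read alike.

The compounds shown leave open whether the methyl on the phenyl ring contributes to this result. They also leave open how a sulfonyl group carrying a pyridine ring, an amine or a carboxylic acid would read.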